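Neopentyl for isopropyl across two amine and amide pairs

The source may hold more compounds than are shown below. What is called first, only, known or untested is meant among the compounds shown, and "the series" means these compounds.

Compound 1 `CC(C)(C)Cn1cc2c(Cl)nc(N)nc2n1` and compound 2 `CC(C)n1cc2c(Cl)nc(N)nc2n1` share a core that carries a free amine, while compound 3 `CC(C)n1cc2c(Cl)nc(NC(=O)c3ccc(F)cc3)nc2n1` carries an amide instead. The difference between the core of compound 3 and that of compound 2 is not broken down here. In an assay on CHO cells for displacement of a labelled ligand from adenosine receptor A1 (Homo sapiens), read by scintillation counting, with a stated time of 3 h (on this read-out higher numbers stand for weaker inhibition and lower numbers for stronger inhibition), compound 2 gives 9000 nM, compound 1 gives 12000 nM, and compound 3 gives 3400 nM, the lowest number of the three. Compound 1 differs from compound 2 by neopentyl in place of isopropyl on an aromatic nitrogen, a step of a 1.3-fold higher number from compound 2 to compound 1 (0.12 log units; within the scatter). Compound 4 `CC(C)(C)Cn1cc2c(Cl)nc(NC(=O)c3ccc(F)cc3)nc2n1` has not yet been measured in this assay; it differs from compound 3 by neopentyl in place of isopropyl on an aromatic nitrogen, the same change at the same place. Since the earlier step was a 1.3-fold higher number from compound 2 to compound 1 (0.12 log units; within the scatter), a step of about a 1.3-fold higher number from compound 3 to compound 4 (0.10 log units; within the scatter) is expected here as well. Compound 4 is therefore estimated at 4300 nM, between 2000 nM and 9500 nM.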

Compound 4, inhibition constant: 16500 nM
The estimate for compound 4 lay 3.8-fold (0.58 log units) below the measured number; measured number outside the range, above it.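

In this assay, neopentyl in place of isopropyl on an aromatic nitrogen gives a 4.9-fold higher number from compound 3 to compound 4 (0.69 log units; beyond the scatter) on the amide core. The size of this step does not carry over from the free amine core to the amide core: the same change on two cores in this assay, a 1.3-fold higher number (0.12 log units; within the scatter) from compound 2 to compound 1 and a 4.9-fold higher number (0.69 log units; beyond the scatter) from compound 3 to compound 4, 3.6-fold (0.56 log units) apart, beyond the scatter of two such steps

The change therefore cannot be treated as a fixed increment in this series, although two pairs show neither the cause of the gap nor how the change would behave on a third core.

Still open, from the compounds shown here alone, is whether a core bearing an acetamide or an unsubstituted benzamide would follow the amine pair or the amide pair. Also open, going by these compounds, is how an ethyl or a cyclobutyl on the aromatic nitrogen would compare on these two cores.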